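A few compounds are considered here, and "the series" means these few. Any claim that something is new, unique, unknown or untested is made for them only; others in the source may bear on it.

Compound 1 `CC(C)N(Cc1cccc(OCCCCCC(=O)O)c1)C(=O)c1ccc(-c2ccncc2)cc1`, compound 2 `COc1cccc(-c2ccc(C(=O)N(Cc3cccc(OCCCCCC(=O)O)c3)C(C)C)cc2)c1` and compound 3 `CC(C)N(Cc1cccc(OCCCCCC(=O)O)c1)C(=O)c1ccc(-c2ccc3[nH]ccc3c2)cc1` share one core and differ only in the aryl group carried on an aromatic carbon. In an ADME assay on HepG2 cells (Homo sapiens) for cytotoxicity, read by CellTiter-Glo and resazurin assay, with a stated time of 72 h (a lower number here means that less compound is needed, a higher number that more compound is needed for the effect), compound 1 gives > 26000 nM, which is a limit of the assay. In this assay compound 2 gives > 26000 nM, also a limit. In this assay compound 3 gives > 26000 nM, again a limit, so compound 3 stands level with the two others shown. Because every value sits at the limit of > 26000 nM in this assay, at which 3 of the 3 values shown sit, the steps a step that the two limits leave unreadable from compound 1 to compound 2, a step that the two limits leave unreadable from compound 1 to compound 3 and a step that the two limits leave unreadable from compound 2 to compound 3 cannot be sized. Compound 4 `CC(C)N(Cc1cccc(OCCCCCC(=O)O)c1)C(=O)c1ccc(-c2cccc(OC(F)(F)F)c2)cc1` follows from compound 3 by 3-(trifluoromethoxy)phenyl in place of 1H-indol-5-yl on an aromatic carbon. Among the compounds with values here, none of the measured steps gives a readable size for exchanging one aryl group for another, so no step beyond the scatter is expected. Compound 4 is estimated at 26000 nM, with a range from 18000 nM to 40000 nM, an expected step of a number no higher from compound 3 to compound 4 (the limit leaves the size open).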

Compound 4, half-maximal effective concentration: > 26000 nM
Compound 4 ended at the assay's limit; the forecaster's own chance of this, stated with the estimate: 85%; the middle value sits exactly at the limit.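

The steps from compound 1, compound 2 and compound 3 to compound 4 cannot be read, as all values sit at one limit: the limit of > 26000 nM in this assay, at which 4 of the 4 values shown sit.

The concentration each of these compounds needs for the effect in this assay stays open, and with it whether exchanging the aryl group changes that concentration.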